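A few compounds are considered here, and "the series" means these few. Any claim that something is new, unique, unknown or untested is made for them only; others in the source may bear on it.

Working notes on the series. Of the compounds shown here, two have numbers so far. Compound 1, `CC(C)(C)c1ccc(CNCCCNS(=O)(=O)c2cc(C(F)(F)F)cc(C(F)(F)F)c2)cc1`, and compound 2, `O=S(=O)(NCCCCNCc1ccc(Br)cc1)c1cc(C(F)(F)F)cc(C(F)(F)F)c1`, share a bis(trifluoromethyl)phenylsulfonamide core with a saturated chain leading to a benzylamine. In a functional assay on Capan-2 cells (Homo sapiens) for inhibition, read by MTT assay, with a stated time of 72 h (a lower number here means a stronger inhibitor of growth, a higher number a weaker inhibitor of growth), compound 1 gives 2100 nM, and in this assay compound 2 gives 1900 nM. Compound 2 has the lower of the two numbers, but the gap to compound 1 lies within the scatter, so the two are not told apart by these measurements.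

Compound 3, `O=S(=O)(NCCCNCc1ccc(Cl)c(Cl)c1)c1cc(C(F)(F)F)cc(C(F)(F)F)c1`, is the next compound in the series and has not yet been measured. It differs from compound 2 in one place: (3,4-dichlorobenzyl)amino in place of ((4-bromobenzyl)amino)methyl on a saturated chain carbon, three bonds along the chain from a sulfonamide nitrogen. For the measured compounds named here, no measured pair here shows such a change, so the size of the step cannot be read from the numbers in hand. With both measured compounds sitting within the scatter of each other and the shared core unchanged, no step beyond the scatter is expected from compound 2 to compound 3 in this assay, in either direction.

For compound 3 the number in this assay is estimated at 2000 nM, with a range from 900 nM to 4500 nM, an expected step of a 1.1-fold higher number from compound 2 to compound 3 (0.02 log units; within the scatter).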

Compound 3, concentration for 50% growth inhibition: 1800 nM
The estimate for compound 3 lay 1.1-fold (0.05 log units) above the measured number; the measured number falls inside the stated range.
By their numbers in this assay, from the lowest: compounds 3, 2 and 1 (each within the scatter of the next).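

In this assay, (3,4-dichlorobenzyl)amino in place of ((4-bromobenzyl)amino)methyl on a saturated chain carbon, three bonds along the chain from a sulfonamide nitrogen, gives a 1.1-fold lower number from compound 2 to compound 3 (0.02 log units; within the scatter), so this first readable step at that position stays inside the scatter. For the compounds shown here, with 3,4-dichlorophenyl in place of 4-(tert-butyl)phenyl on a saturated chain carbon bound to an amine nitrogen, the result is a 1.2-fold lower number from compound 1 to compound 3 (0.07 log units; within the scatter), and that change also leaves the compounds not told apart, with no compound among the three going against this. No measured evidence on these compounds bears on why these steps are so small.

The change linking compound 2 and compound 3 alters the chain and the halogens on the ring in one replacement, so a contribution from either part alone cannot be separated, and opposing contributions are not ruled out. On these data alone, whether a carboxylic acid or a methoxy group on that ring, an amide in place of the amine, or a longer chain would give a step beyond the scatter in this assay remains open.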